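Methyl for methylsulfonyl on a fused heteroaromatic core

The source may report more compounds than this note shows. Statements on the series, on what has been measured and on what is new or still open speak of the compounds shown alone.

Measured compounds:
compound 1 `CCSc1nn2cc(-c3cc4ccccc4o3)nc2s1` gives 2900 nM in a functional assay on HEK293 cells for antagonist activity at proteinase-activated receptor 4 (Homo sapiens), read by FLIPR and calcium flux, with a stated time of 30 min; on this read-out lower numbers stand for stronger inhibition and higher numbers for weaker inhibition
compound 2 `CS(=O)(=O)c1nn2cc(-c3cc4ccccc4o3)nc2s1` gives 820 nM
compound 3 `COc1cc(OCc2ccccc2OCc2ccccc2)c2cc(-c3cn4nc(OC)sc4n3)oc2c1` gives 3.2 nM

Compound 2 stands second highest of the three numbers in this assay; its nearest neighbour is compound 1, and compound 3 lies far below it. Going by the values given here, the step of a 3.5-fold lower number from compound 1 to compound 2 (0.55 log units; beyond the scatter) is the only measured change at the position in question, and it shows that swapping one group for another on the aromatic carbon of the five-membered ring with two nitrogens and one sulfur shifts the number by a modest but real amount.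

Compound 4 `Cc1nn2cc(-c3cc4ccccc4o3)nc2s1` has not yet been tested in this assay. It differs from compound 2 by methyl in place of methylsulfonyl on an aromatic carbon. Among the compounds with values here, no measured pair shows this exact exchange, so the expectation rests on compound 1 and compound 2 alone: the group that enters resembles neither of theirs, but it lacks the acceptors of the group that leaves, as does compound 1. Compound 4 is therefore expected to give a somewhat higher number than compound 2, with the step of a 2.4-fold higher number from compound 2 to compound 4 (0.39 log units; beyond the scatter) estimated. The estimate for compound 4 is 2000 nM, expected to fall between 600 nM and 7000 nM.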

Compound 4, half-maximal inhibitory concentration: 37 nM
Estimate against measurement, compound 4: 54-fold (1.73 log units) above; the whole stated range lies above it.
By their numbers in this assay, from the lowest: compound 3; then compound 4; then compound 2; then compound 1.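

In this assay, methyl at this aromatic carbon changes the picture left by the earlier pair, whose exchange of groups had produced only a modest shift (a 3.5-fold lower number from compound 1 to compound 2 (0.55 log units; beyond the scatter)). Replacing methylsulfonyl with methyl gives a large step (a 22-fold lower number from compound 2 to compound 4 (1.35 log units; beyond the scatter)), and replacing ethylsulfanyl with methyl gives a larger one still (a 78-fold lower number from compound 1 to compound 4 (1.89 log units; beyond the scatter)). On this shared core, the position is therefore far more sensitive to the choice of group than the first pair showed, and the order from lowest number to highest runs methyl, methylsulfonyl, ethylsulfanyl.

The compounds shown leave open whether this gain is particular to methyl or would also appear with an ethyl group, an amine or a chlorine atom at the same carbon. Nothing available accounts for the size of these steps.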